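This account rests on a few compounds, and the source may have more. Where it says the series, first, only, none or still open, it means among the compounds named here.

In an ADME assay on HS27 cells (Homo sapiens) for antiproliferative activity, read by MTT assay, with a stated time of 24 h (a lower number here means a stronger inhibitor, a higher number a weaker inhibitor), compound 3 `Nc1ncnc2c1ccn2-c1ccc(NC(=O)c2ccc(Cl)c(C(F)(F)F)c2)cc1` gives 5600 nM, which is the highest of the two numbers shown; its nearest neighbour is compound 1 `O=C(Nc1ccc(-n2ccc3c(NC(=O)c4ccccc4)ncnc32)cc1)c1ccc(Cl)c(C(F)(F)F)c1`, which in this assay gives 5500 nM. Compound 2 `CC(=O)Nc1ncnc2c1ccn2-c1ccc(NC(=O)Nc2cccc(Cl)c2Cl)cc1` in this assay returns only a limit, > 10000 nM. Going by the values given here, the one measured step is a 1.0-fold higher number from compound 1 to compound 3 (0.01 log units; within the scatter), so removing the benzoyl from that nitrogen leaves the number essentially where it was. Compound 4 `CC(=O)Nc1ncnc2c1ccn2-c1ccc(NC(=O)c2ccc(Cl)c(C(F)(F)F)c2)cc1` differs from compound 3 by acetyl in place of hydrogen on a nitrogen on an aromatic ring. The step from compound 1 to compound 3 is the only one that bears on it, and it shows that an acyl group on this nitrogen neither raised nor lowered the number beyond the scatter. Compound 2 carries the same acetyl group but a different linker, and it sits at the limit (the limit of > 10000 nM in this assay, at which 1 of the 3 values shown sits), so it gives no number to compare. For compound 4 the step from compound 3 is therefore expected to be a 1.2-fold higher number from compound 3 to compound 4 (0.06 log units; within the scatter), that is, none beyond the scatter. Compound 4 is estimated to give 6500 nM in this assay, with a range from 2500 nM to 15000 nM.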

Compound 4, half-maximal inhibitory concentration: > 10000 nM
Compound 4 ended at the assay's limit; the forecaster's own chance of this, stated with the estimate: 25%; at least 1.5-fold (0.18 log units) between middle value and limit.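

In this assay compound 4 returns a limit and not a number, and such limits now make up a larger share of the values shown: the limit of > 10000 nM in this assay, at which 2 of the 4 values shown sit. Compound 1 and compound 3 alone suggested that acylating this nitrogen changes nothing beyond the scatter, but placing acetyl on the amino group of compound 3 gives an at least 1.7-fold higher number from compound 3 to compound 4 (0.25 log units; that floor lies within the scatter), a floor that leaves open a larger rise than benzoyl produced. Methyl in place of phenyl on the carbonyl carbon gives an at least 1.8-fold higher number from compound 1 to compound 4 (0.25 log units; that floor lies within the scatter), so acetyl and benzoyl need not behave alike at this nitrogen, although neither floor by itself establishes a change beyond the scatter.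

On these data alone, the true size of both steps remains unknown, and the step between compound 2 and compound 4 cannot be read, since both values are limits. The compounds shown also leave open where other groups on this nitrogen would fall, such as propionyl, with a longer chain on the carbonyl carbon, or methanesulfonyl, which has no carbonyl at all.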